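Iodo to methoxy: working notes on compound 2

This account rests on a few compounds, and the source may have more. Where it says the series, first, only, none or still open, it means among the compounds named here.

In a functional assay on U-251 cells (Homo sapiens) for inhibition (a lower number here means a stronger inhibitor of growth, a higher number a weaker inhibitor of growth), compound 1 `NC(=O)c1cc(Cl)ccc1NC(=O)COc1ccccc1` gives 2340 nM and compound 2 `NC(=O)c1cc(I)ccc1NC(=O)COc1ccccc1` gives 396 nM. Compound 2 therefore holds the lower of the two numbers and is the stronger inhibitor of growth of this pair. Going by the values given here, the one measured step, with iodo in place of chloro on an aromatic carbon, is a 5.9-fold lower number from compound 1 to compound 2 (0.77 log units; beyond the scatter).

Compound 3 `COc1ccc(NC(=O)COc2ccccc2)c(C(N)=O)c1` keeps the shared core but has methoxy in place of iodo on an aromatic carbon, meta to a carbamoyl group and para to a large group: methoxy in place of iodo on an aromatic carbon.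

Among the compounds with values here, no methoxy compound has yet been measured, so the halogen pair is the only guide. It shows that a change at this carbon can move the number beyond the scatter. Within the data shown here, compound 2 has the lowest number so far at 396 nM, and replacing its iodo is expected to give up much of that standing, though this rests on a single step. The expected step is a 5.1-fold higher number from compound 2 to compound 3 (0.70 log units; beyond the scatter), towards a weaker inhibitor and similar in size to the halogen step. Compound 3 is estimated at 2000 nM, with an expected range of 600 nM to 7000 nM.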

Compound 3, concentration for 50% growth inhibition: 664 nM
The estimate for compound 3 lay 3.0-fold (0.48 log units) above the measured number; the range from low to high includes it.
By their numbers in this assay, from the lowest: compounds 2 and 3 (each within the scatter of the next); then compound 1.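

In this assay, methoxy in place of iodo on an aromatic carbon is a 1.7-fold higher number from compound 2 to compound 3 (0.22 log units; within the scatter) and leaves compound 2 and compound 3 not separable, so among the compounds shown, a halogen at this carbon, meta to a carbamoyl group and para to a large group, is not required to reach this level. Methoxy in place of chloro is a 3.5-fold lower number from compound 1 to compound 3 (0.55 log units; beyond the scatter) and therefore places compound 1 alone as the weaker member of the set, with compound 2 and compound 3 both clear of it, so the outcome at this carbon does not follow a simple halogen versus non-halogen split, since chloro goes against iodo while methoxy stays with iodo. Nothing measured here explains why methoxy, with its 2 heavy atoms and 1 hydrogen-bond acceptor, stands with iodo rather than with chloro.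

Still open, going by these compounds, is whether an amine, a carboxylic acid or a longer alkoxy chain at this carbon would stay with compound 2 and compound 3 or drop towards compound 1. All three compounds keep the carbamoyl group and the rest of the shared core unchanged, so they say nothing about how replacing the phenoxy group, for example with a benzyloxy group, would read in this assay alongside these changes.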